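A few compounds are considered here, and "the series" means these few. Any claim that something is new, unique, unknown or untested is made for them only; others in the source may bear on it.

Measured compounds:
compound 1, `COc1ccc(-c2nnc(N3CCN(C(=O)CN4CCN(c5ccccc5OC)CC4)CC3)nc2-c2ccc(OC)cc2)cc1`, > 821000 nM
compound 2, `COc1ccc(-c2nnc(N3CCN(C(=O)CN4CCN(c5ccc([N+](=O)[O-])cc5)CC4)CC3)nc2-c2ccc(OC)cc2)cc1`, > 801000 nM
compound 3, `COc1ccccc1N1CCN(CC(=O)N2CCN(c3nnc(-c4ccc(Cl)cc4)c(-c4ccc(Cl)cc4)n3)CC2)CC1`, 405000 nM

Within the data shown here, in an ADME assay on NIH3T3 cells (Mus musculus) for cytotoxicity, read by MTT assay, with a stated time of 24 h (on this read-out lower numbers stand for stronger inhibition and higher numbers for weaker inhibition), compound 3 gives the only actual number of the three; the other two results are limits of the assay. For compound 1 the result is a limit, (the limit of > 821000 nM in this assay, at which 1 of the 3 values shown sits). For compound 2 the result likewise is a limit, (the limit of > 801000 nM in this assay, at which 1 of the 3 values shown sits). Among the measured compounds shown here, the one pair that differs in a single place is compound 1 and compound 2, but the step that the two limits leave unreadable from compound 1 to compound 2 is unreadable, as both values are limits.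

Compound 4, `COc1cccc(N2CCN(CC(=O)N3CCN(c4nnc(-c5ccc(Cl)cc5)c(-c5ccc(Cl)cc5)n4)CC3)CC2)c1`, is not yet measured. It differs from compound 3 as follows: 3-methoxyphenyl in place of 2-methoxyphenyl on an amine nitrogen in a ring. No measured step concerns a change of this kind: the only step shown swaps a 4-nitrophenyl for a 2-methoxyphenyl, and its size cannot be read. Nothing in the numbers therefore points in either direction, and the expectation is that the step of no change at the digits printed from compound 3 to compound 4 (within the scatter) stays within the usual scatter. Compound 4 is accordingly estimated to show 405000 nM in this assay, with a range from 150000 nM to 900000 nM, and a result reported only as a limit, as for compound 1 and compound 2, remains a real possibility.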

Compound 4, half-maximal inhibitory concentration: 202000 nM
Beside the measured number, compound 4's estimate is 2.0-fold (0.30 log units) above it; the range from low to high includes it.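

In this assay, among these compounds, the exchange of 2-methoxyphenyl for 3-methoxyphenyl on an amine nitrogen in a ring gives a 2.0-fold lower number from compound 3 to compound 4 (0.30 log units; within the scatter) and provides the first readable step at this place. The earlier step at this place, between compound 1 and compound 2, cannot be read because both results are limits, so only the new pair shows that these two methoxyphenyl groups cannot be separated on this read-out when they sit on the core of compound 3. No available measurement bears on why the two compounds read as they do, and the pair alone gives no ground for assigning any property to either group.

Whether the same holds beyond this one exchange remains open, since the compounds shown do not tell how a 4-methoxyphenyl, a plain phenyl or a carboxylic acid on the same ring nitrogen would read in this assay. From the compounds shown here alone, it also remains open whether 3-methoxyphenyl and 2-methoxyphenyl would read alike on the core of compound 1, whose own result is only a limit.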